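The source may hold more compounds than are shown below. What is called first, only, known or untested is meant among the compounds shown, and "the series" means these compounds.

In a functional assay on HCT-116 cells (Homo sapiens) for antiproliferative activity (on this read-out lower numbers stand for stronger inhibition and higher numbers for weaker inhibition), two compounds of this series have been measured. Compound 1 `Cc1c2c(n3c1CCN(C(=O)[C@H](C)N)CC[C@H](C)Nc1cc-3ccc1C(N)=O)CC(C)(C)CC2=O` gives 314 nM in this assay. Compound 2 `COCCC(=O)N1CCc2c(C)c3c(n2-c2ccc(C(N)=O)c(c2)N[C@@H](C)[C@H](C)C1)CC(C)(C)CC3=O` gives 38 nM in this assay, the lowest number of the two, with compound 1 standing beyond the usual scatter above it. The step of interest leads from compound 2 to compound 3 `Cc1c2c(n3c1CCN(C(=O)[C@@H](O)C(C)C)C[C@@H](C)[C@H](C)Nc1cc-3ccc1C(N)=O)CC(C)(C)CC2=O`, which is not yet measured in this assay. The change is confined to one place: 1-hydroxy-2-methylpropyl in place of 2-methoxyethyl on a carbonyl carbon. Within the data shown here, no measured pair in this set differs in this place alone, so the size of the step rests on expectation rather than on a recorded step. Compound 3 is expected to move by a 1.6-fold higher number from compound 2 to compound 3 (0.20 log units; within the scatter) in this assay, a small step that may not go beyond the scatter, leaning toward a slightly higher number. Compound 3 is therefore estimated at 60 nM in this assay, within a range from 20 nM to 200 nM.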

Compound 3, half-maximal inhibitory concentration: 45 nM
The estimate for compound 3 lay 1.3-fold (0.12 log units) above the measured number, and the stated range covers the measured number.
By their numbers in this assay, from the lowest: compounds 2 and 3 (each within the scatter of the next); then compound 1.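

On a carbonyl carbon whose other neighbour is an amide-type nitrogen in a ring, placing 1-hydroxy-2-methylpropyl where 2-methoxyethyl stood gives, in this assay, a 1.2-fold higher number from compound 2 to compound 3 (0.07 log units; within the scatter) and so no change that this read-out can resolve. Among these compounds, this is the first recorded step at this position, and it shows that the position accepts a chain carrying a hydrogen-bond donor and a defined stereocentre, neither of which 2-methoxyethyl has, with the number remaining within the scatter. Nothing available accounts for how small this step is.

The compounds shown leave open whether an amine, a carboxylic acid or a longer chain on this carbonyl carbon would also stay within the scatter in this assay. They also leave open whether the opposite configuration at the stereocentre of 1-hydroxy-2-methylpropyl would give a similar number.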